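The source may report more compounds than this note shows. Statements on the series, on what has been measured and on what is new or still open speak of the compounds shown alone.

Measured so far in a functional assay on A549 cells (Homo sapiens) for inhibition, read by MTT assay, with a stated time of 48 h; a higher number here means a weaker inhibitor of growth, a lower number a stronger inhibitor of growth:
- Compound 1 `Cn1cc(C2CC(c3ccccc3)=NN2C(=O)c2cccnc2)c2ccccc21`: > 10000 nM
- Compound 2 `Cc1ccc(C(=O)N2N=C(c3ccccc3)CC2c2cn(C)c3ccccc23)cn1`: 1190 nM

The entry for compound 1, > 10000 nM, is a limit of the assay and not a number. Going by the values given here, compound 2, at 1190 nM, therefore holds the only true number so far, and there is no spread of values to place it in. Among the compounds with values here, the one measured step is an at least 8.4-fold lower number from compound 1 to compound 2 (0.92 log units; beyond the scatter), and it came with methyl in place of hydrogen on an aromatic carbon.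

Compound 3 `Cn1cc(C2CC(c3ccccc3)=NN2C(=O)c2cccnc2Cl)c2ccccc21` differs from compound 2 as follows: 2-chloropyridin-3-yl in place of 6-methylpyridin-3-yl on a carbonyl carbon. In words, it has 2-chloropyridin-3-yl in place of 6-methylpyridin-3-yl on a carbonyl carbon. Within the data shown here, compound 3 loses the methyl group of compound 2 at 1190 nM, and no measured compound carries chlorine, so the earlier gain need not carry over. That single step is thus only a rough guide. The expected change is a 2.9-fold higher number from compound 2 to compound 3 (0.47 log units; beyond the scatter), a modest move towards weaker growth inhibition. For compound 3 the estimated value is 3500 nM, with an expected range of 1000 nM to 10000 nM.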

Compound 3, concentration for 50% growth inhibition: > 10000 nM
Compound 3 was reported as a limit; the forecaster's own chance of this, stated with the estimate: 25%; middle value at least 2.8-fold (0.45 log units) from the limit.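

In this assay, putting 2-chloropyridin-3-yl in place of 6-methylpyridin-3-yl on the carbonyl carbon comes with an at least 8.4-fold higher number from compound 2 to compound 3 (0.92 log units; beyond the scatter), so the growth inhibition of compound 2 is not kept and a substituent on this ring is not enough on its own. Compound 3 gives > 10000 nM, which is a limit of the assay and not a number, so the step has a minimum size but no exact one. The step from compound 1 to compound 3 cannot be read, because both entries are limits: the limit of > 10000 nM in this assay, at which 2 of the 3 values shown sit.

The names 6-methylpyridin-3-yl and 2-chloropyridin-3-yl differ in both the group and its number on the ring, so these compounds cannot separate the loss of methyl, the arrival of chloro and the change of place. Going by these compounds, it also remains open whether a methoxy group or an amine in place of the methyl would keep, improve or lose the growth inhibition seen with compound 2.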